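The source may hold more compounds than are shown below. What is called first, only, known or untested is meant among the compounds shown, and "the series" means these compounds.

Measured compounds:
compound 1 `COc1ccc(C(=O)/C=C/c2ccc(N3CCCC3)cc2)c2c1C=CC(C)(C)O2` — 6180 nM
compound 2 `COc1ccc(C(=O)/C=C/c2ccc(OC)c(OC)c2OC)c2c1C=CC(C)(C)O2` — > 10000 nM
compound 3 `COc1ccc(C(=O)/C=C/c2cccc(C(F)(F)F)c2)c2c1C=CC(C)(C)O2` — 7850 nM

Of the compounds shown here, three sharing one core have been tested in a functional assay on K562 cells (Homo sapiens) for antiproliferative activity, read by MTT assay, with a stated time of 24 h; on this read-out higher numbers stand for weaker inhibition and lower numbers for stronger inhibition. Compound 1 `COc1ccc(C(=O)/C=C/c2ccc(N3CCCC3)cc2)c2c1C=CC(C)(C)O2` gives 6180 nM in this assay. Compound 3 `COc1ccc(C(=O)/C=C/c2cccc(C(F)(F)F)c2)c2c1C=CC(C)(C)O2` gives 7850 nM, a number that sits within the usual scatter of the number for compound 1, so the two cannot be told apart. Compound 2 `COc1ccc(C(=O)/C=C/c2ccc(OC)c(OC)c2OC)c2c1C=CC(C)(C)O2` is reported only as a limit of this assay, > 10000 nM, with no number behind it; this is the limit of > 10000 nM in this assay, at which 1 of the 3 values shown sits. Taken together, none of the three reaches a strong inhibition, and the spread among them is narrow.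

The next compound, compound 4 `COc1ccc(C(=O)/C=C/c2ccc(Cl)cc2)c2c1C=CC(C)(C)O2`, has not yet been measured in this assay. It differs from compound 1 in a single place: chloro in place of pyrrolidin-1-yl on an aromatic carbon. Among the measured compounds shown here, no step between two measured compounds describes a change of this kind, so its size can only be guessed from the general weakness of the series. Compound 4 is expected to stay in the same weak region, with a step of a 1.3-fold higher number from compound 1 to compound 4 (0.11 log units; within the scatter) that is not expected to exceed the scatter. The estimate for compound 4 in this assay is 8000 nM, with a range from 3000 nM to 20000 nM.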

Compound 4, half-maximal inhibitory concentration: > 10000 nM
Compound 4 was reported as a limit; the forecaster's own chance of this, stated with the estimate: 35%; middle value at least 1.2-fold (0.09 log units) from the limit.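

In this assay, chloro in place of pyrrolidin-1-yl on this aromatic carbon, para to a large group, gives an at least 1.6-fold higher number from compound 1 to compound 4 (0.20 log units; that floor lies within the scatter), so this change brings no gain in inhibition, while the floor of the step alone does not separate the two compounds. This is the only pair shown that differs in one place, and it sets a five-membered non-aromatic ring with one hetero atom against a single chlorine, with no sign that chloro does better here. Compound 4 is reported only as a limit, so the full size of the step cannot be read, and the series gains no new number at this position: the limit of > 10000 nM in this assay, at which 2 of the 4 values shown sit.

The compounds shown leave open whether another group on this aromatic carbon, such as a dimethylamino group, a morpholine ring or a carboxylic acid, would give a number clearly apart from that of compound 1. With a single step, and a limit at one end of it, they also leave open whether any change at this place can move the series out of its weak region.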